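Replacing 4-chlorophenyl with 2-methoxyphenyl on the shared core

The compounds below may be only part of what the source reports. "The series", "measured", "known", "first", "only" and "open" are said of these compounds alone.

In a functional assay (aorta) with Oryctolagus cuniculus as the target (a higher number here means weaker binding, a lower number tighter binding), compound 1 `CC(=O)c1ccc(OCCCN2CCC(C(c3ccc(F)cc3)c3ccc(F)cc3)CC2)cc1` gives 2.51 nM, compound 2 `N#Cc1ccc(OCCCN2CCC(C(c3ccc(F)cc3)c3ccc(F)cc3)CC2)cc1` gives 5.01 nM, and compound 3 `Fc1ccc(C(c2ccc(F)cc2)C2CCN(CCCOc3ccc(Cl)cc3)CC2)cc1` gives 2 nM. Compound 3 stands close to one neighbour and apart from the other: the data show a 1.3-fold lower number from compound 1 to compound 3 (0.10 log units; within the scatter), and also a 2.5-fold lower number from compound 2 to compound 3 (0.40 log units; beyond the scatter). The remaining comparison gives a 2.0-fold higher number from compound 1 to compound 2 (0.30 log units; within the scatter).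

The next compound, compound 4 `COc1ccccc1OCCCN1CCC(C(c2ccc(F)cc2)c2ccc(F)cc2)CC1`, carries 2-methoxyphenyl in place of 4-chlorophenyl on an oxygen on a saturated carbon. The three measured steps bear on this change only indirectly. Each exchanges one group on an aromatic carbon for another, among acetyl, cyano and chloro, and none of them involves a 2-methoxyphenyl group. They therefore offer no direct test of the new group. They do show that the exchanges tried so far moved the number only a little, the largest being a 2.5-fold lower number from compound 2 to compound 3 (0.40 log units; beyond the scatter), which is a modest step. On that basis, no large shift is expected in this assay, and any change is expected to stay within the scatter. The estimated change is a 1.5-fold higher number from compound 3 to compound 4 (0.18 log units; within the scatter). Compound 4 is estimated at 3 nM, with an expected range from 1 nM to 10 nM.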

Compound 4, dissociation constant: 2.51 nM
Compound 4: the middle estimate sits 1.2-fold (0.08 log units) above what was measured, within the range that was stated.
By their numbers in this assay, from the lowest: compounds 3, 1, 4 and 2 (each within the scatter of the next, the first and the last beyond it).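

The 2-methoxyphenyl group is the only one here that is not a 4-substituted phenyl, and on this oxygen on a saturated carbon it cannot be told apart from any of the three earlier groups in this assay: against 4-chlorophenyl (a 1.3-fold higher number from compound 3 to compound 4 (0.10 log units; within the scatter)), against 4-cyanophenyl (a 2.0-fold lower number from compound 2 to compound 4 (0.30 log units; within the scatter)) and against 4-acetylphenyl (no change at the digits printed from compound 1 to compound 4 (within the scatter)). Compound 4 therefore lies within the scatter of compounds 1, 2 and 3 alike, even though compounds 2 and 3 are separated beyond it, so this position keeps its reading with a different substitution on the phenyl ring and with a group that counts one hydrogen-bond acceptor where 4-chlorophenyl counts none. No measurement at hand offers a reason for this result.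

Because the group and its place on the ring change together, the comparison does not separate them, and 4-methoxyphenyl and 2-chlorophenyl on the same oxygen would be the compounds to do so. On these data alone, how an amine or a carboxylic acid on the phenyl ring would read at this position also remains open, as does a longer chain in place of the one that carries the oxygen.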